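The source may report more compounds than this note shows. Statements on the series, on what has been measured and on what is new or still open speak of the compounds shown alone.

Values in a functional assay with Rattus norvegicus as the target; a higher number here means a weaker inhibitor, a lower number a stronger inhibitor:
- compound 1 `COc1ccc2[nH]c(=O)c(=O)oc2c1`: 28000 nM
- compound 2 `O=c1[nH]c2ccc(O)cc2oc1=O`: 170000 nM
- compound 3 `Cc1ccc2[nH]c(=O)c(=O)oc2c1`: 32000 nM

Compound 3 sits level with compound 1, and well apart from compound 2. Compound 4 `N#Cc1ccc2[nH]c(=O)c(=O)oc2c1` has cyano in place of methyl on an aromatic carbon. Two measured steps swap groups on that same carbon. Swapping methoxy for methyl gave a 1.1-fold higher number from compound 1 to compound 3 (0.06 log units; within the scatter), while swapping hydroxy for methyl gave a 5.3-fold lower number from compound 2 to compound 3 (0.73 log units; beyond the scatter). The step of a 6.1-fold higher number from compound 1 to compound 2 (0.78 log units; beyond the scatter) shows the same contrast. Going by the values given here, only hydroxy stands apart, and no measured compound carries cyano, so the direction stays open. In this assay the expected change is small, likely within the scatter: a 1.1-fold lower number from compound 3 to compound 4 (0.03 log units; within the scatter). For compound 4 the estimated value is 30000 nM, with an expected range of 10000 nM to 100000 nM.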

Compound 4, half-maximal inhibitory concentration: 15000 nM
For compound 4 the middle estimate is 2.0-fold (0.30 log units) above the measured one; low and high end bracket the measured number.
By their numbers in this assay, from the lowest: compounds 4, 1 and 3 (each within the scatter of the next, the first and the last beyond it); then compound 2.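

In this assay cyano parts from methyl on this aromatic carbon, with a 2.1-fold lower number from compound 3 to compound 4 (0.33 log units; beyond the scatter) as a modest gain in strength, something methoxy did not do. Cyano and methoxy stay level, with a 1.9-fold lower number from compound 1 to compound 4 (0.27 log units; within the scatter) inside the usual scatter. Hydroxy remains the outlier, with an 11-fold lower number from compound 2 to compound 4 (1.05 log units; beyond the scatter) as the largest step in the set. On these data alone, how an amine, a carboxylic acid or a chlorine on this carbon would compare with cyano stays open. Nothing available here accounts for these differences.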